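Series notes: aryl swap on the sulfinyl-bearing carbon

This account rests on a few compounds, and the source may have more. Where it says the series, first, only, none or still open, it means among the compounds named here.

Compound 1 `Cc1nnc(C[S+]([O-])C(c2ccccc2)c2ccccc2)s1` is reported without a number, as "not active" (no number reported), in an assay on HEK293 cells for inhibition of sodium-dependent dopamine transporter (Homo sapiens), read by scintillation counting, with stated times of 5 min and 1 min; on this read-out higher numbers stand for weaker inhibition and lower numbers for stronger inhibition. Compound 2 `COC1NN=C(C[S+]([O-])C(c2ccccc2)c2ccccc2)S1` gives 108000 nM in this assay, and compound 3 `[O-][S+](Cc1csc(Br)c1)C(c1ccccc1)c1ccccc1` gives 16600 nM, the lowest of the two numbers, with compound 2 nearest at a 6.5-fold lower number from compound 2 to compound 3 (0.81 log units; beyond the scatter). Compound 4 `[O-][S+](Cc1cc(C2CC2)on1)C(c1ccccc1)c1ccccc1` differs from compound 3 only in 5-cyclopropyl-1,2-oxazol-3-yl in place of 5-bromothiophen-3-yl on a saturated chain carbon bound to a sulfur. Among the compounds with values here, the single step that bears on this position is that from compound 2 to compound 3, a modest one; the ring entering in compound 4 resembles neither, and compounds 1 and 2, whose rings carry more hetero atoms, are the weaker entries. A step toward a higher number is therefore expected, a 2.4-fold higher number from compound 3 to compound 4 (0.38 log units; beyond the scatter), and compound 4 is estimated at 40000 nM, within 12000 nM to 150000 nM.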

Compound 4, half-maximal inhibitory concentration: 38600 nM
The estimate for compound 4 lay 1.0-fold (0.02 log units) above the measured number; low and high end bracket the measured number.
By their numbers in this assay, from the lowest: compound 3; then compound 4; then compound 2.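

In this assay, 5-cyclopropyl-1,2-oxazol-3-yl in place of 5-bromothiophen-3-yl on a saturated chain carbon bound to a sulfur gives a 2.3-fold higher number from compound 3 to compound 4 (0.37 log units; beyond the scatter), while the same group against that of compound 2 gives a 2.8-fold lower number from compound 2 to compound 4 (0.45 log units; beyond the scatter). This position therefore accepts a second hetero atom in the aromatic ring and an added cyclopropyl, with compound 4 lying between compound 3 and compound 2. Nothing measured here accounts for either step.

As far as these compounds go, whether the cyclopropyl or the ring carries the step remains open. So does whether an amine or a carboxylic acid in place of the cyclopropyl would give a lower number than compound 3.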